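Swapping the Naphthyl Head for a Chloro-Trifluoromethylphenyl Group

A few compounds are considered here, and "the series" means these few. Any claim that something is new, unique, unknown or untested is made for them only; others in the source may bear on it.

In a functional assay on MIA PaCa-2 cells (Homo sapiens) for inhibition, read by MTT assay, with a stated time of 72 h (a lower number here means a stronger inhibitor of growth, a higher number a weaker inhibitor of growth), compound 1 `O=S(=O)(NCCCNCc1cccc2ccccc12)c1cc(C(F)(F)F)cc(C(F)(F)F)c1` gives 2800 nM, the lowest of the three numbers in hand. Within the data shown here, compound 2 `CC(C)c1ccc(S(=O)(=O)NCCCCCCNCc2ccc(Br)cc2)cc1` gives 5730 nM and compound 3 `O=S(=O)(NCCCCCCNCc1ccc(Br)cc1)c1c(Cl)cccc1Cl` gives 14700 nM; the only single-point step among them, a 2.6-fold higher number from compound 2 to compound 3 (0.41 log units; beyond the scatter), concerns the group on the sulfonyl sulfur and not the group on the amine side. Compound 4 `O=S(=O)(NCCCNCc1ccc(Cl)c(C(F)(F)F)c1)c1cc(C(F)(F)F)cc(C(F)(F)F)c1` differs from compound 1 in that other place: 4-chloro-3-(trifluoromethyl)phenyl in place of naphthalen-1-yl on a saturated chain carbon bound to an amine nitrogen. Among the measured compounds shown here, no measured step touches the saturated chain carbon bound to an amine nitrogen, so the account can lean on nothing but the size of the step seen elsewhere. A modest step is expected in this assay, with the direction uncertain. Compound 4 is therefore estimated at 3500 nM, within 1200 nM to 10000 nM. That estimate means an expected step of a 1.3-fold higher number from compound 1 to compound 4 (0.10 log units; within the scatter).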

Compound 4, concentration for 50% growth inhibition: 7400 nM
Beside the measured number, compound 4's estimate is 2.1-fold (0.33 log units) below it; low and high end bracket the measured number.
By their numbers in this assay, from the lowest: compound 1; then compounds 2, 4 and 3 (each within the scatter of the next, the first and the last beyond it).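

Measured in this assay, the group on a saturated chain carbon bound to an amine nitrogen now has a step of its own: 4-chloro-3-(trifluoromethyl)phenyl in place of naphthalen-1-yl gives a 2.6-fold higher number from compound 1 to compound 4 (0.42 log units; beyond the scatter). The position therefore responds to this change, and the direction favours naphthalen-1-yl for this one pair. No evidence at hand accounts for this step. Going by these compounds, whether a plain phenyl, 4-chlorophenyl or naphthalen-2-yl group here would fall nearer compound 1 or compound 4 remains open. So does whether the step would persist with a longer chain.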